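The source may report more compounds than this note shows. Statements on the series, on what has been measured and on what is new or still open speak of the compounds shown alone.

Measured compounds:
- compound 1 `CCCCCCCC/C=C\CCCCCCCC(=O)Nc1nnc(S[C@@H]2O[C@H](COC(C)=O)[C@H](OC(C)=O)[C@H](OC(C)=O)[C@H]2OC(C)=O)s1`, in an ADME assay on CHO-K1 cells (Cricetulus griseus) for cytotoxicity, read by MTT assay, with a stated time of 24 h (on this read-out higher numbers stand for weaker inhibition and lower numbers for stronger inhibition), compound 1 gives 26300 nM
- compound 2 `CCCCCCCC(=O)Nc1nnc(S[C@@H]2O[C@H](CO)[C@H](O)[C@H](O)[C@H]2O)s1`, in this assay compound 2 gives 60100 nM
- compound 3 `CCCCCCCCCCCCCCCCCC(=O)Nc1nnc(S[C@@H]2O[C@H](CO)[C@H](O)[C@H](O)[C@H]2O)s1`, in this assay compound 3 gives "not active" (no number reported), with no number given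

All three share the same core and differ in the chain attached through the amide. Compound 3 carries the longest chain, and on the numbers shown it stands apart: it has no single value, only the statement that no inhibition was found. Compound 2, with a much shorter chain, does give a number, and compound 1 gives a lower one still, though compound 1 also differs from the others elsewhere in its core.

Compound 4 `C=CCCCCCCCCC(=O)Nc1nnc(S[C@@H]2O[C@H](CO)[C@H](O)[C@H](O)[C@H]2O)s1` is not yet measured. It differs from compound 3 by vinyl in place of nonyl on a saturated chain carbon, eight bonds along the chain from a carbonyl carbon. The chain thus becomes shorter, between those of compound 2 and compound 3 in length, with a double bond at its end.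

Because compound 2 gives 60100 nM in this assay while compound 3 gives no number, the step from compound 3 to compound 4 is expected to move toward a measurable value, likely by a modest amount in the direction of stronger inhibition. For compound 4 in this assay the expected value is 70000 nM, within a range from 25000 nM to 200000 nM.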

Compound 4, half-maximal inhibitory concentration: "not active" (no number reported)
The entry for compound 4 holds no number; there is nothing to compare the estimate with.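

Compound 3 and compound 4 are both reported as "not active" in this assay and carry no number, so no step can be read between them. The compounds shown leave open whether the change from nonyl to vinyl shifts this read-out at all. Nothing measured here offers a reason for either result.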